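The compounds below may be only part of what the source reports. "The series", "measured", "known", "first", "only" and "open" are said of these compounds alone.

Measured in a functional assay on L1210 cells (Mus musculus) for antiproliferative activity, with a stated time of 48 h; on this read-out lower numbers stand for stronger inhibition and higher numbers for weaker inhibition:
- compound 1 `C=C(Br)C(=O)Nc1ccc(/C=C/C(=O)c2ccc(F)cc2)cc1`: 1600 nM
- compound 2 `Nc1ccc(/C=C/C(=O)c2ccc(F)cc2)cc1`: 123000 nM
- compound 3 `Nc1ccc(/C=C/C(=O)c2ccc(Cl)c(Cl)c2)cc1`: 26000 nM

Of these three, compound 2 stands highest at 123000 nM, and it is the weakest inhibitor of the set. Compound 4 `COc1ccc(C(=O)/C=C/c2ccc(N)cc2)cc1` has not yet been measured. It departs from compound 2 by a single change, methoxy in place of fluoro on an aromatic carbon.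

Only one measured step links two of these compounds through a single change, and it says little here. For the measured compounds named here, the step of a 77-fold higher number from compound 1 to compound 2 (1.89 log units; beyond the scatter) is large and beyond the scatter, but it is hydrogen in place of (1-bromoethenyl)carbonyl on a nitrogen on an aromatic ring, which is a different place from the one that changes now. Compound 2 differs in its halogens from the closest guide, compound 3, which reads 26000 nM, a lower number. Going by the values given here, no measured step covers the swap of fluoro for methoxy, so only a modest shift toward a lower number is expected, and it may not clear the scatter.

In this assay the expected step is a 1.8-fold lower number from compound 2 to compound 4 (0.24 log units; within the scatter). For compound 4 the estimated value is 70000 nM, with an expected range of 25000 nM to 160000 nM.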

Compound 4, half-maximal inhibitory concentration: 160000 nM
Compound 4: the middle estimate sits 2.3-fold (0.36 log units) below what was measured, within the range that was stated.
By their numbers in this assay, from the lowest: compound 1; then compound 3; then compounds 2 and 4 (each within the scatter of the next).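

In this assay, putting methoxy in place of fluoro on this aromatic carbon, para to a large group, gives a 1.3-fold higher number from compound 2 to compound 4 (0.11 log units; within the scatter), so the read-out does not tell the two groups apart at this position. For the compounds shown here, this is the first measured step at this place, as the only earlier step concerned the group on the nitrogen, and it shows that a hydrogen-bond acceptor entering here, where fluoro counted none, comes with no shift beyond the scatter in this pair. No measurement of any property of these compounds bears on this result.

The compounds shown leave open whether a group of another kind on this aromatic carbon, such as an amine or a carboxylic acid, would move the number beyond the scatter. They also leave open whether fluoro and methoxy would still read alike with the (1-bromoethenyl)carbonyl on the nitrogen, the form carried by compound 1 at 1600 nM, for which the methoxy partner is not among the compounds shown.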